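Quinone in Place of Hydroquinone on a Pyrazole Sulfonamide

This account rests on a few compounds, and the source may have more. Where it says the series, first, only, none or still open, it means among the compounds named here.

Measured compounds:
compound 1 `COc1ccc(OC)c(-c2cc(-c3ccccc3)nn2-c2ccc(S(=O)(=O)NC(C)=O)cc2)c1`: 28800 nM
compound 2 `CC(=O)NS(=O)(=O)c1ccc(-n2nc(-c3ccccc3)cc2-c2cc(O)ccc2O)cc1`: 100000 nM

In a functional assay on cells (Cancer cell lines, Homo sapiens) for cytotoxicity, read by sulforhodamine B assay, with a stated time of 48 h (a higher number here means a weaker inhibitor of growth, a lower number a stronger inhibitor of growth), compound 2 gives 100000 nM, the highest of the two numbers recorded. Its nearest neighbour is compound 1, and the step of a 3.5-fold higher number from compound 1 to compound 2 (0.54 log units; beyond the scatter) separates them. Compound 3 `CC(=O)NS(=O)(=O)c1ccc(-n2nc(-c3ccccc3)cc2C2=CC(=O)C=CC2=O)cc1` has not yet been measured. Its difference from compound 2 is a group of 8 heavy atoms (6 carbon, 2 oxygen; one six-membered non-aromatic ring of carbon only) in place of a group of 8 heavy atoms (6 carbon, 2 oxygen; one six-membered aromatic ring of carbon only), on an aromatic carbon. For the measured compounds named here, no measured step involves the group that enters here, so none bears on the change directly. Going by the values given here, the one recorded step shows that swapping the ring bearing two oxygens for another of the same size moved this assay only modestly, which suggests the next swap may also be moderate. The direction is open. For compound 3 the expected step is a 2.5-fold lower number from compound 2 to compound 3 (0.40 log units; beyond the scatter). Compound 3 is estimated at 40000 nM, within 8000 nM to 150000 nM.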

Compound 3, concentration for total growth inhibition: 100000 nM
Compound 3: the middle estimate sits 2.5-fold (0.40 log units) below what was measured; measured number inside the range.
By their numbers in this assay, from the lowest: compound 1; then compounds 2 and 3 (each within the scatter of the next).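

In this assay, putting the non-aromatic ring with its 0 hydrogen-bond donors in place of 2,5-dihydroxyphenyl with its 2 gives no change at the digits printed from compound 2 to compound 3 (within the scatter), so at this aromatic carbon neither the donors nor the aromatic ring makes a difference that can be read between these two compounds. Measured against the 2,5-dimethoxyphenyl group, the new ring gives a 3.5-fold higher number from compound 1 to compound 3 (0.54 log units; beyond the scatter), a step of the same size as a 3.5-fold higher number from compound 1 to compound 2 (0.54 log units; beyond the scatter). Compound 1, with its 2,5-dimethoxyphenyl group, therefore remains the strongest inhibitor of growth of the three, and only its group stands apart at this position.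

Nothing measured here accounts for these numbers. Going by these compounds, it remains open whether a carboxylic acid, an amine or a longer alkoxy chain on this ring would give a number lower than that of compound 1.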